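The source may hold more compounds than are shown below. What is called first, only, known or untested is meant among the compounds shown, and "the series" means these compounds.

In an assay on isolated protein with malate dehydrogenase, cytoplasmic (Sus scrofa) as the target (on this read-out lower numbers stand for stronger inhibition and higher numbers for weaker inhibition), compound 1 `O=C(O)c1ccc2c(O)c(C(=O)O)cnc2c1` gives 1290000 nM, while compound 2 `NS(=O)(=O)c1ccc2c(O)c(C(=O)O)cnc2c1` gives 692000 nM. Compound 2 stands lowest of the two numbers shown, although the step of a 1.9-fold lower number from compound 1 to compound 2 (0.27 log units; within the scatter) lies within the scatter. Compound 3 `NC(=O)c1ccc2c(O)c(C(=O)O)cnc2c1` differs from compound 2 by carbamoyl in place of sulfamoyl on an aromatic carbon. Among the measured compounds shown here, the only measured step bearing on this position, a 1.9-fold lower number from compound 1 to compound 2 (0.27 log units; within the scatter), was within the scatter, so in this assay the expected step of a 1.2-fold higher number from compound 2 to compound 3 (0.09 log units; within the scatter) is likewise none beyond the scatter. Compound 3 is accordingly estimated at 850000 nM, within a range from 350000 nM to 2000000 nM.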

Compound 3, half-maximal inhibitory concentration: 603000 nM
Compound 3: the middle estimate sits 1.4-fold (0.15 log units) above what was measured; the measured number falls inside the stated range.
By their numbers in this assay, from the lowest: compounds 3, 2 and 1 (each within the scatter of the next, the first and the last beyond it).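

In this assay, carbamoyl in place of sulfamoyl on this aromatic carbon leaves the number within the scatter (a 1.1-fold lower number from compound 2 to compound 3 (0.06 log units; within the scatter)). Amino in place of hydroxy on the carbonyl carbon gives the first step at this position to pass the scatter, though only modestly (a 2.1-fold lower number from compound 1 to compound 3 (0.33 log units; beyond the scatter)). No evidence is available to explain this step. The compounds shown leave open whether an amine or a longer chain on this aromatic carbon would give a number beyond the scatter of these three.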